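This account rests on a few compounds, and the source may have more. Where it says the series, first, only, none or still open, it means among the compounds named here.

Compound 1 `O=C(Nc1ccc(F)cc1)c1c(NO)cc(-c2ccccc2)oc1=O`: > 20000 nM, a limit of the assay
Compound 2 `Cc1ccc(NC(=O)c2c(NO)cc(-c3ccc(F)cc3)oc2=O)cc1`: > 20000 nM, a limit of the assay
Compound 3 `CNC(=O)c1c(NO)cc(-c2ccc(OC)cc2)oc1=O`: > 20000 nM, a limit of the assay

In an ADME assay on Huh-7 cells (Homo sapiens) for cytotoxicity, read by a luciferase reporter and WST assay, with a stated time of 3 days (a lower number here means that less compound is tolerated, a higher number that more compound is tolerated), compound 1 gives no number, only a limit, and it stands at the limit of > 20000 nM in this assay, at which 3 of the 3 values shown sit. Compound 4 `COC(=O)CNC(=O)c1c(NO)cc(-c2ccccc2)oc1=O` has not been measured; it differs from compound 1 in one place, with (methoxycarbonyl)methyl in place of 4-fluorophenyl on an amide-type nitrogen. Going by the values given here, no step between two measured compounds is available to show what such a change does here. Because every measured value sits at the limit of > 20000 nM in this assay, at which 3 of the 3 values shown sit, the step in this assay from compound 1 to compound 4 is expected to be none beyond the scatter, with the result most likely again only a limit: a step that the limit leaves unreadable from compound 1 to compound 4. Compound 4 is therefore expected at 30000 nM, with a range from 10000 nM to 100000 nM.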

Compound 4, half-maximal cytotoxic concentration: > 20000 nM
Compound 4 gave a limit, no number; the forecaster's own chance of this, stated with the estimate: 85%; the middle value lies beyond the limit too.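

In this assay, compound 1 and compound 4 each give only a limit, so no step between them can be read: the limit of > 20000 nM in this assay, at which 4 of the 4 values shown sit.

The compounds shown leave open at what concentration any of them becomes cytotoxic, and whether (methoxycarbonyl)methyl in place of 4-fluorophenyl changes that concentration.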